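A few compounds are considered here, and "the series" means these few. Any claim that something is new, unique, unknown or untested is made for them only; others in the source may bear on it.

Values in a toxicity assay on MDCK cells (Canis lupus familiaris) for cytotoxicity, read by CCK-8 assay, with a stated time of 48 h; a higher number here means that more compound is tolerated, a lower number that less compound is tolerated:
- Compound 1 `COc1ccc(C(=O)NNc2c(Br)cccc2Br)cc1`: > 100000 nM (a limit)
- Compound 2 `CCCOc1ccc(C(=O)NNc2c(Br)cccc2Br)cc1`: > 100000 nM (a limit)
- Compound 3 `O=C(NNc1c(Br)cccc1Br)c1ccc(F)cc1`: > 100000 nM (a limit)

Compound 3 stands only at a limit, > 100000 nM, so no actual number is known for it in this assay. The other two compounds give no number either, and all that the series offers is the limit of > 100000 nM in this assay, at which 3 of the 3 values shown sit.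

Compound 4 `O=C(NNc1c(Br)cccc1Br)c1ccc(Br)cc1` differs from compound 3 in one place: bromo in place of fluoro on an aromatic carbon. This is bromo in place of fluoro on an aromatic carbon. The measured changes at that aromatic carbon are a step that the two limits leave unreadable from compound 1 to compound 3 and a step that the two limits leave unreadable from compound 2 to compound 3. The remaining measured change, in the chain, is a step that the two limits leave unreadable from compound 1 to compound 2. None of these has a readable size, so they point in neither direction, and no shift beyond the scatter is expected. Compound 4 may well be reported as a limit too. The expected step is a number no higher from compound 3 to compound 4 (the limit leaves the size open). The estimated value for compound 4 is 100000 nM, with an expected range from 50000 nM to 200000 nM.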

Compound 4, half-maximal cytotoxic concentration: > 100000 nM
Compound 4 ended at the assay's limit; the forecaster's own chance of this, stated with the estimate: 85%; the middle value sits exactly at the limit.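

Among the compounds shown here, no step to compound 4 from compound 1, compound 2 or compound 3 can be read in this assay, as the series offers only one thing: the limit of > 100000 nM in this assay, at which 4 of the 4 values shown sit. The compounds shown leave open the actual half-maximal cytotoxic concentration of each, and whether bromo, fluoro, methoxy or propoxy makes any difference.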